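Difluoromethyl for Methyl on the Shared Core

This account rests on a few compounds, and the source may have more. Where it says the series, first, only, none or still open, it means among the compounds named here.

Measured compounds: compound 1 `Cc1ccc(Nc2nc(N)nc(COc3ccc4c(C)cc(=O)oc4c3)n2)cc1` with 1790 nM; compound 2 `Cc1cc(=O)oc2cc(OCc3nc(N)nc(Nc4ccc(C5CC5)cc4)n3)ccc12` with 700 nM; compound 3 `Cc1cc(=O)oc2cc(OCc3nc(N)nc(Nc4cccc(O)c4)n3)ccc12` with "not determined" (no result reported).

In an assay on COS-7 cells for agonist activity at Free fatty acid receptor 1 (Homo sapiens), read by scintillation counting and inositol phosphate accumulation, with a stated time of 90 min (on this read-out higher numbers stand for an effect only at larger amounts of compound and lower numbers for an effect already at smaller amounts), compound 1 gives the highest of the two numbers; the nearest is compound 2, reached by a 2.6-fold lower number from compound 1 to compound 2 (0.41 log units; beyond the scatter). Compound 4 `Cc1ccc(Nc2nc(N)nc(COc3ccc4c(C(F)F)cc(=O)oc4c3)n2)cc1` differs from compound 1 by difluoromethyl in place of methyl on an aromatic carbon. For the measured compounds named here, no measured step touches this place on the shared core: the only known step, from compound 1 to compound 2, changes a different part of the molecule, so it gives no direct guide. With nothing bearing on the change, the expectation is a step no larger than the scatter, a 1.2-fold lower number from compound 1 to compound 4 (0.08 log units; within the scatter). Compound 4 is therefore estimated at 1500 nM, within 450 nM to 5000 nM.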

Compound 4, half-maximal effective concentration: 3180 nM
Compound 4: the middle estimate sits 2.1-fold (0.33 log units) below what was measured; measured number inside the range.
By their numbers in this assay, from the lowest: compound 2; then compounds 1 and 4 (each within the scatter of the next).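

In this assay, difluoromethyl in place of methyl on this aromatic carbon, opposite the ring oxygen, gives a 1.8-fold higher number from compound 1 to compound 4 (0.25 log units; within the scatter) and is the only step shown at this position. Within the compounds shown, this place on the shared core accepts the two added fluorine atoms with no change that stands clear of the usual scatter. Nothing available explains this outcome.

On these data alone, whether trifluoromethyl, an amine or a carboxylic acid at this place would give a step beyond the scatter stays open. Also open, as far as these compounds go, is whether difluoromethyl would give a similar step alongside the cyclopropyl of compound 2.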